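From amino to ethyl on the shared core

The source may hold more compounds than are shown below. What is called first, only, known or untested is meant among the compounds shown, and "the series" means these compounds.

Values in a functional assay on aorta (Rattus norvegicus, strain Wistar); on this read-out higher numbers stand for weaker inhibition and lower numbers for stronger inhibition:
compound 1 `CC(=O)c1ccc2c(c1)N(C1=CCCC1=O)CC(C)(C)S2`: 1.45 nM
compound 2 `CC(=O)Nc1ccc2c(c1)N(C1=CCCC1=O)CC(C)(C)S2`: 6610 nM
compound 3 `CC1(C)CN(C2=CCCC2=O)c2cc(N)ccc2S1`: 3980 nM
compound 4 `CCc1ccc2c(c1)N(C1=CCCC1=O)CC(C)(C)S2`: not yet measured

Compound 3, at 3980 nM, stands close to compound 2, with a 1.7-fold lower number from compound 2 to compound 3 (0.22 log units; within the scatter), but far from compound 1. Compound 4 differs from it by ethyl in place of amino on an aromatic carbon. The nearest evidence at this carbon is a 2700-fold higher number from compound 1 to compound 3 (3.44 log units; beyond the scatter) and a 4600-fold higher number from compound 1 to compound 2 (3.66 log units; beyond the scatter), both large. Among the measured compounds shown here, no measured compound carries ethyl, so this assay offers only these bounds, and a sizeable move towards compound 1 is expected, stopping well short of it. The expected change is a 20-fold lower number from compound 3 to compound 4 (1.30 log units; beyond the scatter). Compound 4 is estimated at 200 nM, with an expected range from 15 nM to 2500 nM.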

Compound 4, half-maximal inhibitory concentration: 155 nM
Estimate against measurement, compound 4: 1.3-fold (0.11 log units) above, within the range that was stated.
By their numbers in this assay, from the lowest: compound 1; then compound 4; then compounds 3 and 2 (each within the scatter of the next).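

In this assay ethyl on this aromatic carbon stands well apart from amino and acetamido with a 26-fold lower number from compound 3 to compound 4 (1.41 log units; beyond the scatter) and a 43-fold lower number from compound 2 to compound 4 (1.63 log units; beyond the scatter) yet falls short of acetyl with a 110-fold higher number from compound 1 to compound 4 (2.03 log units; beyond the scatter) at the same carbon. The earlier compounds shown here showed only two far-apart levels here. Compound 4 adds a third level between them with a group that carries no hydrogen-bond donor or acceptor, so not every carbon-attached group matches acetyl.

On these data alone, whether a longer chain such as propyl, or a methoxy group, would come closer to compound 1 remains open. No measurement offered here explains the order of these groups.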